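Aryl urea hydrazone series: hydroxyl-to-methoxy change on the arylidene

A few compounds are considered here, and "the series" means these few. Any claim that something is new, unique, unknown or untested is made for them only; others in the source may bear on it.

Measured compounds:
compound 1 `CN(C)CCn1cnnc1-c1cc(Oc2ccc(NC(=O)N/N=C/c3cccc(O)c3)cc2F)ccn1` — > 100000 nM
compound 2 `CN(C)CCn1cnnc1-c1cc(Oc2ccc(NC(=O)N/N=C/c3ccc(O)cc3)cc2F)ccn1` — 3560 nM
compound 3 `Cc1cc(/C=N/NC(=O)Nc2ccc(Oc3ccnc(-c4nncn4CCN(C)C)c3)c(F)c2)cc(C)c1O` — 1640 nM

In a functional assay on A549 cells (Homo sapiens) for cytotoxicity, read by MTT assay, with a stated time of 72 h (on this read-out higher numbers stand for weaker inhibition and lower numbers for stronger inhibition), compound 1 reaches only a limit, > 100000 nM, with no number. Compound 2 gives 3560 nM and compound 3 gives 1640 nM, the lowest of the two numbers shown; the step of a 2.2-fold lower number from compound 2 to compound 3 (0.34 log units; beyond the scatter) is modest. The steps from the limit, an at least 28-fold lower number from compound 1 to compound 2 (1.44 log units; beyond the scatter) and an at least 60-fold lower number from compound 1 to compound 3 (1.78 log units; beyond the scatter), are large, and both concern the 3-hydroxyphenyl against a 4-hydroxyphenyl or a 4-hydroxy-3,5-dimethylphenyl.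

Compound 4 `COc1ccc(/C=N/NC(=O)Nc2ccc(Oc3ccnc(-c4nncn4CCN(C)C)c3)c(F)c2)c(OC)c1` differs from compound 3 by 2,4-dimethoxyphenyl in place of 4-hydroxy-3,5-dimethylphenyl on a carbon with a double bond to nitrogen. For the measured compounds named here, no measured step covers a change of this kind: the hydroxyl that is present in compounds 2 and 3 leaves, and two methoxy groups enter. The measured steps only show that the arylidene group is sensitive to substitution and that the substitution pattern can shift the number past the limit. For compound 4 a weaker result than compound 3 is therefore expected, with wide uncertainty, as a step of a 4.3-fold higher number from compound 3 to compound 4 (0.63 log units; beyond the scatter). Compound 4 is estimated at 7000 nM, within 1500 nM to 60000 nM.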

Compound 4, half-maximal inhibitory concentration: 2820 nM
Beside the measured number, compound 4's estimate is 2.5-fold (0.39 log units) above it; low and high end bracket the measured number.
By their numbers in this assay, from the lowest: compounds 3, 4 and 2 (each within the scatter of the next, the first and the last beyond it). At a limit, above all of these: compound 1.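

In this assay, a hydroxyl on the ring at this carbon proves not to be needed: 2,4-dimethoxyphenyl, which carries none, gives a 1.7-fold higher number from compound 3 to compound 4 (0.24 log units; within the scatter) and a 1.3-fold lower number from compound 2 to compound 4 (0.10 log units; within the scatter), so it cannot be told apart from either hydroxylated group. The same group also separates clearly from 3-hydroxyphenyl, with an at least 35-fold lower number from compound 1 to compound 4 (1.54 log units; beyond the scatter), so the presence of a hydroxyl does not by itself set the result in this small set. That step is read against compound 1, whose entry is a limit and not a number: the limit of > 100000 nM in this assay, at which 1 of the 4 values shown sits.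

Open, as far as these compounds go, is how 2-methoxyphenyl or 4-methoxyphenyl alone, or a phenyl carrying an amine or a carboxylic acid, would read on this carbon. The compounds shown also give no reason why 3-hydroxyphenyl stands so far from the other groups.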